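The source may report more compounds than this note shows. Statements on the series, on what has been measured and on what is new or still open speak of the compounds shown alone.

Compound 1, `Cc1cc(-n2ccc3ccncc32)ccc1C#N`: > 99%
Compound 2, `COc1ccc(Oc2cc(Oc3cccnc3)ccc2C#N)cc1`: 84%

Of the compounds shown here, two have been measured in an assay on isolated protein for inhibition of Aromatase (Homo sapiens), read by fluorescence, tested at 1 uM; a lower number here means less inhibition, a higher number more inhibition at the concentration tested (going by the name of the read-out). In this assay compound 1 gives > 99%, and that value is a limit of the assay rather than a number; it sits at the limit of > 99% in this assay, at which 1 of the 2 values shown sits. Among the measured compounds shown here, compound 2 gives 84% in this assay, which is the only number in the set. Compound 2 therefore stands as the sole fixed point from which a neighbour can be judged.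

Compound 3, `N#Cc1ccc(Oc2cccnc2)cc1Oc1ccccc1`, has not been measured. It differs from compound 2 by hydrogen in place of methoxy on an aromatic carbon. For the measured compounds named here, no measured pair with this kind of change is available here, so nothing in the set shows how large such a step is. The step is expected to be modest, a small fall in inhibition, a number 8 percentage points lower from compound 2 to compound 3 (within the scatter), and it may not exceed the usual scatter. Compound 3 is accordingly estimated at 76%, with a range from 52% to 92%.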

Compound 3, a percentage reported as inhibition, at one concentration (the size of the read-out at that concentration, not a potency): 78%
Compound 3: the middle estimate sits 2 percentage points below what was measured, and the stated range covers the measured number.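

In this assay, among the compounds shown here, compounds 2 and 3 form the first pair in the set that differs in only one place, and the step reads a number 6 percentage points lower from compound 2 to compound 3 (within the scatter). On this aromatic carbon, para to a large group, methoxy can therefore give way to hydrogen, turning 4-methoxyphenyl into phenyl, with no change that stands clear of the usual scatter. Nothing at hand speaks to why the step is this size.

From the compounds shown here alone, whether a different group at this place, such as an amine, a carboxylic acid or a fluorine atom, would move the read-out beyond the scatter remains open. Also open, going by these compounds, is how these compounds relate to compound 1, which differs from them in more than one place, and how they rank in potency, since each has a reading at only one concentration.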